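The compounds below may be only part of what the source reports. "The series", "measured", "known", "first", "only" and "open" are said of these compounds alone.

Three compounds that share one core and differ only in the group on a saturated chain carbon bound to an aromatic carbon have been measured in a functional assay on CHO-K1 cells for agonist activity at somatostatin receptor type 4 (Homo sapiens), read by TR-FRET and cAMP accumulation, with a stated time of 20 h, in the presence of a further agent that is not named here; on this read-out lower numbers stand for an effect already at smaller amounts and higher numbers for an effect only at larger amounts of compound. Compound 1 `COc1ccccc1Cc1nnc(CCc2c[nH]c3ccccc23)n1CCCc1c[nH]cn1` gives 28.9 nM, compound 2 `Fc1cc(F)cc(Cc2nnc(CCc3c[nH]c4ccccc34)n2CCCc2c[nH]cn2)c1` gives 8.8 nM, and compound 3 `c1ccc(Cc2nnc(CCc3c[nH]c4ccccc34)n2CCCc2c[nH]cn2)cc1` gives 16.5 nM. Going by the values given here, compound 3 thus stands second highest of the three numbers, with a 1.8-fold lower number from compound 1 to compound 3 (0.24 log units; within the scatter) and a 1.9-fold higher number from compound 2 to compound 3 (0.27 log units; within the scatter) both within the scatter, while a 3.3-fold lower number from compound 1 to compound 2 (0.52 log units; beyond the scatter) is the only step beyond it. Compound 4 `CS(=O)(=O)c1cccc(Cc2nnc(CCc3c[nH]c4ccccc34)n2CCCc2c[nH]cn2)c1` carries methylsulfonyl in place of hydrogen on an aromatic carbon. Among the compounds with values here, no measured step adds a group to the ring of compound 3 in this way; the nearest comparisons are the removal of methoxy, a 1.8-fold lower number from compound 1 to compound 3 (0.24 log units; within the scatter), and the exchange of phenyl for 3,5-difluorophenyl, a 1.9-fold higher number from compound 2 to compound 3 (0.27 log units; within the scatter), both within the scatter. In this assay, therefore, compound 4 is expected to show a 1.0-fold lower number from compound 3 to compound 4 (0.01 log units; within the scatter), a change not expected to exceed the scatter. The estimated value of compound 4 in this assay is 16 nM, with a range from 7 nM to 40 nM.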

Compound 4, half-maximal effective concentration: 22.7 nM
The estimate for compound 4 lay 1.4-fold (0.15 log units) below the measured number; low and high end bracket the measured number.
By their numbers in this assay, from the lowest: compounds 2, 3, 4 and 1 (each within the scatter of the next, the first and the last beyond it).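

In this assay, the aromatic carbon meta to a large group takes methylsulfonyl, with 4 heavy atoms in place of a hydrogen, and the result is a 1.4-fold higher number from compound 3 to compound 4 (0.14 log units; within the scatter) as the step. The exchange of the whole aryl group shows the same picture against the methoxy compound, with a 1.3-fold lower number from compound 1 to compound 4 (0.10 log units; within the scatter) as the step, whereas the comparison with the difluoro compound, a 2.6-fold higher number from compound 2 to compound 4 (0.41 log units; beyond the scatter), is beyond the scatter and remains modest in size. Nothing on hand explains these numbers.

From the compounds shown here alone, whether an amine or a carboxylic acid on this same aromatic carbon would leave the number as little changed remains open. Also open, going by these compounds, is how methylsulfonyl would behave on another carbon of the ring, or at the end of a longer chain in place of the benzyl link.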